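A few compounds are considered here, and "the series" means these few. Any claim that something is new, unique, unknown or untested is made for them only; others in the source may bear on it.

Working notes on the series. In an ADME assay on MCF7 cells (Homo sapiens) for inhibition (on this read-out lower numbers stand for stronger inhibition and higher numbers for weaker inhibition), compound 1 `COC(=O)c1cc2c(F)c(F)c(-n3ccnc3)c(F)c2s1` gives > 100000 nM, which is a limit of the assay. Compound 2 `O=C(c1ccccc1)c1cc2c(F)c(F)c(-n3ccnc3)c(F)c2s1` gives > 60000 nM, which is also a limit, so compound 2 has no readable number. Among the measured compounds shown here, the only measured step, a step that the two limits leave unreadable from compound 1 to compound 2, has no readable size, and it concerns a carbonyl carbon rather than the aromatic carbon changed next. Compound 3 `O=C(c1ccccc1)c1cc2c(F)c(F)c(Sc3ccccc3Br)c(F)c2s1` carries (2-bromophenyl)sulfanyl in place of 1H-imidazol-1-yl on an aromatic carbon. For the measured compounds named here, no measured step covers this exchange, so the only anchor for the expectation is compound 2 at > 60000 nM, a limit. A shift toward stronger inhibition in this assay is expected, of uncertain size, and another limit remains quite possible. The estimated step is an at least 2.0-fold lower number from compound 2 to compound 3 (0.30 log units; that floor lies within the scatter). For compound 3 the estimated value is 30000 nM, with an expected range of 6000 nM to 100000 nM.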

Compound 3, half-maximal inhibitory concentration: > 25000 nM
Compound 3 gave a limit, no number; the forecaster's own chance of this, stated with the estimate: 45%; the middle value is on the limit's open side.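

In this assay compound 3 gives > 25000 nM, which is a limit. Compound 2 gives > 60000 nM, also a limit, so no step can be read between compound 2 and compound 3. The compounds shown leave open whether (2-bromophenyl)sulfanyl in place of 1H-imidazol-1-yl changes inhibition in this assay at all, and by how much.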